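The compounds below may be only part of what the source reports. "The series", "measured", "known", "first", "only" and "open" are said of these compounds alone.

Three compounds have numbers or limits in an ADME assay on HEK293 cells (Homo sapiens) for cytotoxicity, read by resazurin assay, with a stated time of 48 h; on this read-out lower numbers stand for higher toxicity in this test and higher numbers for lower toxicity in this test. Compound 1 `COc1ccc(S(=O)(=O)Nc2ccc(-c3nc4cc(NS(=O)(=O)c5ccc(OC)cc5)ccc4o3)cc2)cc1` gives 48000 nM. Compound 2 `COc1ccc(S(=O)(=O)Nc2ccc3oc(-c4ccc(NC(=O)c5ccc(Cl)s5)cc4)nc3c2)cc1` gives 15000 nM, the lower of the two true numbers available. Compound 3 `COc1c(Br)cccc1C(=O)Nc1ccc(Sc2nc3ccccc3s2)cc1` reads > 100000 nM, which is a limit of the assay and not a number.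

Compound 4 `COc1ccc(S(=O)(=O)Nc2ccc3oc(-c4ccc(NC(=O)C5CCN(C(C)=O)CC5)cc4)nc3c2)cc1` differs from compound 2 in one place, with 1-acetylpiperidin-4-yl in place of 5-chlorothiophen-2-yl on a carbonyl carbon. Going by the values given here, only one measured step involves the departing group: a 3.2-fold lower number from compound 1 to compound 2 (0.51 log units; beyond the scatter), where (5-chlorothiophen-2-yl)carbonyl took the place of (4-methoxyphenyl)sulfonyl on a nitrogen on an aromatic ring. That swap is not the same as this one, so it offers only a rough guide. Still, the modest fall seen on reaching compound 2 at 15000 nM suggests that losing the group may give back a similar amount, so a modest rise is expected in this assay. The expected change is a 2.3-fold higher number from compound 2 to compound 4 (0.37 log units; beyond the scatter). Compound 4 is estimated at 35000 nM, with an expected range of 13000 nM to 95000 nM.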

Compound 4, half-maximal cytotoxic concentration: 34000 nM
The estimate for compound 4 lay 1.0-fold (0.01 log units) above the measured number; the range from low to high includes it.
By their numbers in this assay, from the lowest: compound 2; then compounds 4 and 1 (each within the scatter of the next). At a limit, above all of these: compound 3.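

In this assay, the group on the carbonyl carbon matters on its own: with the amide link kept, 1-acetylpiperidin-4-yl in place of 5-chlorothiophen-2-yl gives a 2.3-fold higher number from compound 2 to compound 4 (0.36 log units; beyond the scatter). Replacing the (4-methoxyphenyl)sulfonyl group on the same nitrogen with (1-acetylpiperidin-4-yl)carbonyl gives a 1.4-fold lower number from compound 1 to compound 4 (0.15 log units; within the scatter), so among these compounds a carbonyl on this nitrogen does not by itself go with a lower number, and the lower number of compound 2 goes with its 5-chlorothiophen-2-yl group. Nothing measured here explains this difference.

From the compounds shown here alone, it remains open whether the lower number follows the chlorine or the thiophene ring, which a thiophen-2-yl group without chlorine on the same carbonyl carbon would help to separate. Going by these compounds, how a piperidin-4-yl group with a free amine in place of the acetylated nitrogen would read is also open.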